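A few compounds are considered here, and "the series" means these few. Any claim that something is new, unique, unknown or untested is made for them only; others in the source may bear on it.

Measured compounds in a functional assay on the whole organism (stomach) for inhibition, with Rattus norvegicus as the target, at a dose of 100 mg/kg by the intraduodenal route; a lower number here means less inhibition, a higher number more inhibition at the dose given (going by the name of the read-out):
compound 1 `Cc1ccc(=O)n(CCC#N)n1` gives 0.2% in this assay.
compound 2 `Cc1ccc(=O)n(CCCCCCC(=N)S)n1` gives 29.5% in this assay.

Compound 2 stands highest of the two numbers recorded in this assay. Its nearest neighbour is compound 1, whose number lies lower by a margin beyond the usual scatter, so the two are plainly distinguished. Among the compounds with values here, no step between measured compounds that differ in a single place has been recorded, so the series so far offers only these two points.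

Compound 3 `Cc1ccc(=O)n(CCCCC(=N)S)n1` is the next compound to be run in this assay. It is reached from compound 2 by the change (a group of 3 heavy atoms (1 carbon, 1 nitrogen, 1 sulfur; no ring) in place of a group of 5 heavy atoms (3 carbon, 1 nitrogen, 1 sulfur; no ring), on a saturated chain carbon, four bonds along the chain from an aromatic nitrogen). The change sits on a saturated chain carbon, four bonds along the chain from an aromatic nitrogen.

Within the data shown here, for this step no measured precedent exists. A step downward in this assay is expected, of a size that may just exceed the scatter, namely a number 11.5 percentage points lower from compound 2 to compound 3 (beyond the scatter). Compound 3 is therefore estimated at 18% in this assay, within a range from 3% to 38%. The estimate is held between the two recorded numbers because compound 2 gives 29.5% while compound 1 gives 0.2%.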

Compound 3, a percentage reported as inhibition, in the whole organism at one dose (the size of the read-out at that dose, not a potency): 29.5%
Beside the measured number, compound 3's estimate is 11.5 percentage points below it, within the range that was stated.
By their numbers in this assay, from the lowest: compound 1; then compounds 2 and 3 (each within the scatter of the next).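

In this assay, placing a group of 3 heavy atoms (1 carbon, 1 nitrogen, 1 sulfur; no ring) in place of a group of 5 heavy atoms (3 carbon, 1 nitrogen, 1 sulfur; no ring), on a saturated chain carbon, four bonds along the chain from an aromatic nitrogen, gives no change at the digits printed from compound 2 to compound 3 (within the scatter), so the longer chain of compound 2 is not required to keep the read-out at this dose. The shorter chain still stands clear of the nitrile compound, with a number 29.3 percentage points higher from compound 1 to compound 3 (beyond the scatter), which shows that the difference from compound 1 survives this shortening. No measurement available bears on why the read-out holds across this change.

The step from compound 1 changes chain length and chain end together, so the compounds shown do not separate the contribution of each. Still open, going by these compounds, are how a shorter chain carrying the same end group would read in this assay, and whether a carboxylic acid or an amine at the chain end would give a similar number.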